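Replacing Isopropyl With 3-Chlorophenyl: Expected Cytotoxicity

The source may report more compounds than this note shows. Statements on the series, on what has been measured and on what is new or still open speak of the compounds shown alone.

Of the compounds shown here, two sharing a five-membered core with two nitrogens have been tested in an ADME assay on Huh-7 cells (Homo sapiens) for cytotoxicity; on this read-out higher numbers stand for lower toxicity in this test and lower numbers for higher toxicity in this test. Compound 1, with structure `CN1CCN(CCNCc2cn(-c3ccc(F)cc3F)nc2-c2ccccc2)CC1`, was measured in this assay and gave only a limit, > 20000 nM. Compound 2, with structure `Cc1ccccc1-c1nn(C(C)C)cc1CNCCN1CCN(C)CC1`, likewise gave only a limit in this assay, > 20000 nM. So compound 2 stands at the upper edge of what this test can report, and both values shown sit at the limit of > 20000 nM in this assay, at which 2 of the 2 values shown sit; neither compound reached a measurable toxicity.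

Compound 3, with structure `Cc1ccccc1-c1nn(-c2cccc(Cl)c2)cc1CNCCN1CCN(C)CC1`, has not yet been measured. It differs from compound 2 as follows: 3-chlorophenyl in place of isopropyl on an aromatic nitrogen.

Among the measured compounds shown here, no pair of measured compounds that differ in one place is available, so there is no measured step to lean on. Given that compound 2 sits at a limit, the expectation for compound 3 is a change of about a step that the limit leaves unreadable from compound 2 to compound 3, which is no more than the usual scatter, with a fair chance that this assay will again report only a limit. Compound 3 is estimated at 25000 nM, within a range from 8000 nM to 80000 nM.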

Compound 3, half-maximal cytotoxic concentration: 16000 nM
Compound 3: the middle estimate sits 1.6-fold (0.19 log units) above what was measured, within the range that was stated.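

In this assay, among the compounds shown here, compound 3 gives the only actual number among the three values shown, so a change at this aromatic nitrogen has now produced a readable cytotoxicity value. Putting 3-chlorophenyl in place of isopropyl gives an at least 1.2-fold lower number from compound 2 to compound 3 (0.09 log units; that floor lies within the scatter), so this step alone does not establish a real shift in toxicity, although a larger shift remains possible. The step can be stated only as a floor because compound 2, at one end of it, carries only a limit: the limit of > 20000 nM in this assay, at which 2 of the 3 values shown sit.

The compounds shown do not separate the contribution of the chlorine from that of the aromatic ring, and a plain phenyl or a cyclohexyl on the same nitrogen would be the kind of group that could tell those two apart. Also open, going by these compounds, is how far the value would move with a larger group here, such as 3-bromophenyl, and whether a measurable value at this position would appear with other groups on the shared core.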